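A Pyrrole Ketone Follows a Furan at the Assay Limit

The compounds below may be only part of what the source reports. "The series", "measured", "known", "first", "only" and "open" are said of these compounds alone.

Measured so far in an ADME assay on RAW264.7 cells (Mus musculus) for cytotoxicity, read by MTT assay; a higher number here means a weaker inhibitor, a lower number a stronger inhibitor:
- Compound 1 `COc1ccc(/C=C/C=C/C(=O)c2ccc(C)cc2)cc1`: "not determined" (no result reported)
- Compound 2 `COc1ccc(/C=C/C=C/C(=O)c2ccc(C)s2)cc1`: "not determined" (no result reported)
- Compound 3 `COc1ccc(/C=C/C=C/C(=O)c2cc(C)oc2C)cc1`: > 100000 nM

Only compound 3 has a reported result, and even that gives no single number. In this assay compound 3 stands at > 100000 nM, which is a limit of the assay. The evidence therefore amounts to the limit of > 100000 nM in this assay, at which 1 of the 3 values shown sits. Among the measured compounds shown here, no pair of measured compounds shows a step, so the size of any change has no direct precedent here.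

Compound 4 `COc1ccc(/C=C/C=C/C(=O)c2ccc[nH]2)cc1` has yet to be measured. It carries 1H-pyrrol-2-yl in place of 2,5-dimethylfuran-3-yl on a carbonyl carbon.

The only anchor for an expectation is compound 3 with its > 100000 nM. The estimated step of an at least 1.2-fold lower number from compound 3 to compound 4 (0.09 log units; that floor lies within the scatter) is small, towards a slightly stronger inhibitor, and may not go beyond the usual scatter. For compound 4 the expected value is 80000 nM, with an estimated range from 25000 nM to 150000 nM.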

Compound 4, half-maximal inhibitory concentration: > 100000 nM
Compound 4 was reported as a limit; the forecaster's own chance of this, stated with the estimate: 60%; at least 1.2-fold (0.09 log units) between middle value and limit.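

In this assay compound 4 gives > 100000 nM, which is a limit of the assay. Among the compounds shown here, compound 3 is also reported only as a limit, so no step between the two can be read. The compounds shown leave open whether 1H-pyrrol-2-yl in place of 2,5-dimethylfuran-3-yl on a carbonyl carbon changes the result in this assay.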